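The source may hold more compounds than are shown below. What is called first, only, known or untested is meant among the compounds shown, and "the series" means these compounds.

Among the measured compounds shown here, compound 1 `Cn1ncc2c(=O)n(-c3ccccc3)c(SC(C)(C)c3ccccc3)nc21` is the weakest of the three compounds measured so far in an assay on isolated protein for inhibition of retinal dehydrogenase 2 (Homo sapiens) (a lower number here means a stronger inhibitor, a higher number a weaker inhibitor), where compound 1 gives 2200 nM. The nearest of the others is compound 3 `CC(Sc1nc2c(cnn2C)c(=O)n1-c1ccc(CO)cc1)c1ccccc1`, which in this assay gives 600 nM, a gap beyond the usual scatter. The furthest is compound 2 `Cn1ncc2c(=O)n(-c3ccccc3)c(SCc3cccc(F)c3)cc21`, which in this assay gives 240 nM, a gap also well beyond the scatter. Compound 1 therefore stands at the high end of the numbers seen here.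

Compound 4 `CC(Sc1nc2c(cnn2C)c(=O)n1-c1ccccc1)c1cccc(F)c1` has not yet been measured in this assay. It differs from compound 1 in one place: 1-(3-fluorophenyl)ethyl in place of 1-methyl-1-phenylethyl on a sulfur. For the measured compounds named here, no pair of measured compounds separated by exactly this change is available, so the size of the step is not fixed directly. Two observations point the same way. The group on the sulfur in compound 4 resembles, apart from the fluorine, that of compound 3, which in this assay gives 600 nM, lower than compound 1. The ring in compound 4 carries the same fluorine as that of compound 2, which in this assay gives 240 nM, also lower than compound 1. On that basis the step from compound 1 to compound 4 is expected to lower the number beyond the scatter, by about a 4.4-fold lower number from compound 1 to compound 4 (0.64 log units; beyond the scatter). Compound 4 is accordingly estimated to give 500 nM in this assay, with a range from 150 nM to 1500 nM.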

Compound 4, half-maximal inhibitory concentration: 110 nM
Compound 4: middle estimate off by 4.5-fold (0.66 log units), on the high side, outside the stated range (below it).
By their numbers in this assay, from the lowest: compound 4; then compound 2; then compound 3; then compound 1.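

Among the compounds shown, this step gives the first direct reading of the group on the sulfur: in this assay, replacing 1-methyl-1-phenylethyl with 1-(3-fluorophenyl)ethyl gives a 20-fold lower number from compound 1 to compound 4 (1.30 log units; beyond the scatter), a large change from one substitution on the shared core. The two groups have the same heavy-atom count and each has one six-membered aromatic ring of carbon only, with no hydrogen-bond donors, hydrogen-bond acceptors or net charge, so the large step comes without any difference in these counts. The change nevertheless removes a methyl group and adds a fluorine in one step, and no measurement offered here bears on why the number falls.

The compounds shown leave open how the step divides between the loss of that methyl group and the gain of the fluorine, as a single pair cannot separate the two. They also leave open whether a chlorine, an amine or a carboxylic acid on the aromatic ring of the 1-(3-fluorophenyl)ethyl group, in place of the fluorine, would keep the number near that of compound 4 at 110 nM.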